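Adding a Methoxy Group: An Expected Cytotoxicity for Compound 4

The source may report more compounds than this note shows. Statements on the series, on what has been measured and on what is new or still open speak of the compounds shown alone.

Four compounds share one core and differ only in the aromatic arm on it. Compound 1 `COc1cccc(/C=C2\CCC/C(=C\c3cccc(OC)c3OC)C2=O)c1` and compound 2 `COc1ccc(/C=C2\CCC/C(=C\c3cccc(OC)c3OC)C2=O)cc1` have the same atoms joined differently: 3-methoxyphenyl in place of 4-methoxyphenyl on a double-bonded chain carbon bound to a double-bonded ring carbon. In an ADME assay on NHDF cells (Homo sapiens) for cytotoxicity, read by MTT assay, with a stated time of 72 h (a lower number here means a stronger inhibitor, a higher number a weaker inhibitor), compound 1 gives 16400 nM, and compound 2 gives 43500 nM, so a 2.7-fold higher number from compound 1 to compound 2 (0.42 log units; beyond the scatter). Compound 3 `COc1ccc(/C=C2\CCC/C(=C\c3cccc(OC)c3OC)C2=O)c(OC)c1` adds one group to compound 2: methoxy in place of hydrogen on an aromatic carbon. In this assay compound 3 gives > 50000 nM, which is a limit of the assay rather than a number. The data include (the limit of > 50000 nM in this assay, at which 1 of the 3 values shown sits). From that follows an at least 1.1-fold higher number from compound 2 to compound 3 (0.06 log units; that floor lies within the scatter). Compound 4 `COc1cc(/C=C2\CCC/C(=C\c3cccc(OC)c3OC)C2=O)cc(OC)c1`, not yet measured, adds the same kind of change to compound 1: methoxy in place of hydrogen on an aromatic carbon. The surroundings differ: in compound 3 the new methoxy is ortho to a large group, in compound 4 it is meta to a large group, and in both it is meta to a methoxy group. In this assay the change is expected to produce a 1.5-fold higher number from compound 1 to compound 4 (0.18 log units; within the scatter), a small rise in the number. That expectation rests on compound 3 and an at least 1.1-fold higher number from compound 2 to compound 3 (0.06 log units; that floor lies within the scatter). Compound 4 is thus expected to give about 25000 nM, likely between 10000 nM and 60000 nM.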

Compound 4, half-maximal inhibitory concentration: 13100 nM
The estimate for compound 4 lay 1.9-fold (0.28 log units) above the measured number; low and high end bracket the measured number.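

In this assay, putting a methoxy group on the aromatic carbon meta to a large group and meta to a methoxy group gives a 1.3-fold lower number from compound 1 to compound 4 (0.10 log units; within the scatter), so this change leaves compound 4 indistinguishable from compound 1. Setting this step beside the one seen on the other core gives a comparison that remains incomplete: the same change on two cores in this assay, an at least 1.1-fold higher number (0.06 log units; that floor lies within the scatter) from compound 2 to compound 3 and a 1.3-fold lower number (0.10 log units; within the scatter) from compound 1 to compound 4; the limit leaves it open whether they differ. The series therefore shows no clear effect of this change on the core of compound 1, but it does not show that the change acts alike on both cores, because compound 3 is reported only as a limit and not as a number: the limit of > 50000 nM in this assay, at which 1 of the 4 values shown sits.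

The compounds shown leave open how far compound 3 really lies from compound 2, and so how closely the two steps agree. They also leave open whether a different group at this place on the ring, such as an amine, a carboxylic acid or a longer chain, would shift the number beyond the scatter.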